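The compounds below may be only part of what the source reports. "The series", "measured", "known", "first", "only" and "open" are said of these compounds alone.

Compound 3, with the structure `COc1ccc(CN(C(=O)C[Se]C#N)c2cc(OC)c(OC)c(OC)c2)cc1O`, gives the lowest of the three numbers recorded so far in a functional assay on MGC-803 cells (Homo sapiens) for inhibition, read by MTT assay, with a stated time of 48 h; on this read-out lower numbers stand for stronger inhibition and higher numbers for weaker inhibition. In this assay compound 3 gives 270 nM. Compound 2, with the structure `COc1ccc(N(Cc2cc(OC)c(OC)c(OC)c2)C(=O)CCl)cc1O`, gives 24500 nM in this assay, and compound 1, with the structure `COc1ccc(CNc2cc(OC)c(OC)c(OC)c2)cc1Br`, gives 29400 nM, so both stand far from compound 3, well beyond the scatter of repeated measurements.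

The next compound, compound 4, has the structure `COc1ccc(CN(C(=O)C(C)C)c2cc(OC)c(OC)c(OC)c2)cc1O`. It differs from compound 3 in one place: a group of 3 heavy atoms (3 carbon; no ring) in place of a group of 4 heavy atoms (2 carbon, 1 nitrogen, 1 selenium; no ring), on a carbonyl carbon. The isopropyl enters on a carbonyl carbon whose other neighbour is an amide-type nitrogen.

Within the data shown here, no two measured compounds differ in exactly one place, so nothing observed tells directly what this change does. Among the measured compounds shown here, what is seen is that compound 3, the only compound carrying the selenium-containing group, gives a number far lower than compounds 1 and 2, which lack it. On that basis the step from compound 3 to compound 4 is expected to be a large one, toward weaker inhibition, well beyond the scatter: a 56-fold higher number from compound 3 to compound 4 (1.74 log units; beyond the scatter). Compound 4 is accordingly estimated to give 15000 nM in this assay, within a range from 3000 nM to 45000 nM.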

Compound 4, half-maximal inhibitory concentration: 210 nM
Estimate against measurement, compound 4: 71-fold (1.85 log units) above; measured number outside the range, below it.
By their numbers in this assay, from the lowest: compounds 4 and 3 (each within the scatter of the next); then compounds 2 and 1 (each within the scatter of the next).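

In this assay, the replacement on the carbonyl carbon gives a 1.3-fold lower number from compound 3 to compound 4 (0.11 log units; within the scatter), so compound 3 and compound 4 cannot be told apart on this read-out. Among these compounds, this is the first direct reading at this position, and it shows that, in this pair, a number in the same range does not depend on the group of 4 heavy atoms with its selenium, nitrogen and triple bond, since isopropyl, made of carbon alone and with no hydrogen-bond acceptor, serves equally well here. No measurement shown explains why the two groups give matching numbers.

Among the compounds shown here, the single step leaves open how far this tolerance extends, and whether a longer chain, a cyclopropyl ring, an amine or a carboxylic acid on the same carbonyl carbon would also stay within the scatter of compound 3 and compound 4. It also leaves open whether the two groups would still match if the rest of the core of compound 3 were altered, as this pair tests only one place.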